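A Fluorine Added to the Benzyl Group of Compound 3

A few compounds are considered here, and "the series" means these few. Any claim that something is new, unique, unknown or untested is made for them only; others in the source may bear on it.

Of the compounds shown here, three have so far been tested in a functional assay on a cell-free system (Platelet, plasma, Homo sapiens), with stated times of 4 min and 5.5 min, tested at 1 uM; a lower number here means a stronger effect, a higher number a weaker effect of the compound at the concentration tested. Compound 1 `O=C(c1cccnc1)N1CCN(c2ncccn2)CC1` gives 74% in this assay. Compound 2 `O=C(c1ccc[n+](Cc2ccccc2F)c1)N1CCN(c2ccccc2Cl)CC1` gives 85%. Compound 3 `O=C(C1CCCN(Cc2ccccc2)C1)N1CCN(c2ccccc2Cl)CC1` gives 22%, which is the lowest of the three numbers and therefore marks the strongest effect seen so far; its nearest neighbour is compound 1, whose number lies well beyond the scatter above it, and compound 2 lies further away still. No two of these measured compounds differ in only one place, so none of these gaps can be tied to a single structural change.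

Compound 4 `O=C(C1CCCN(Cc2ccccc2F)C1)N1CCN(c2ccccc2Cl)CC1` has not yet been measured. It differs from compound 3 in one place: fluoro in place of hydrogen on an aromatic carbon. Everything else in the molecule is kept. Among the measured compounds shown here, on the evidence at hand there is no measured pair that isolates this change, so the expectation rests on the small size of the change alone. The step from compound 3 to compound 4 in this assay is expected to be a number 3 percentage points higher from compound 3 to compound 4 (within the scatter), that is, no change beyond the usual scatter. Compound 4 is accordingly estimated to give 25%, with a range from 10% to 45%.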

Compound 4, a percentage reported as activity, at one concentration (the size of the read-out at that concentration, not a potency): 50%
The estimate for compound 4 lay 25 percentage points below the measured number; measured number above the stated range.
By their numbers in this assay, from the lowest: compound 3; then compound 4; then compound 1; then compound 2.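

In this assay, replacing hydrogen with fluoro on the aromatic carbon, which turns the benzyl group into a 2-fluorobenzyl group, gives a number 28 percentage points higher from compound 3 to compound 4 (beyond the scatter), a weaker effect at the concentration tested. Among the compounds shown here, this is the first pair that differs in only one place, so for the first time a gap in the numbers can be tied to a single structural change. It shows that this position, on a six-membered aromatic ring of carbon only and ortho to a large group, is sensitive: adding just 1 heavy atom there, with everything else in the molecule kept, is enough to move the read-out beyond the usual scatter, and no measurement on hand explains why.

On these data alone, with only this one substituent at this position, it remains open whether the weaker effect is particular to fluoro or would also appear with another group there, such as chloro, methyl or methoxy. As far as these compounds go, it is equally open whether a fluoro on a different carbon of the same ring would give a similar number in this assay.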